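Bromo in place of methoxy on the sulfonyl-bearing ring

The source may hold more compounds than are shown below. What is called first, only, known or untested is meant among the compounds shown, and "the series" means these compounds.

Measured in a functional assay on PC-3 cells (Homo sapiens) for cytotoxicity, read by MTT assay, with a stated time of 72 h; on this read-out higher numbers stand for weaker inhibition and lower numbers for stronger inhibition:
compound 1 `Nc1ccc(Nc2nc3ccccc3nc2S(=O)(=O)c2ccccc2)cc1` — 5830 nM
compound 2 `COc1ccc(S(=O)(=O)c2nc3ccccc3nc2Nc2ccc(N)cc2)cc1` — 9640 nM

Compound 2 stands at the highest of the two numbers, and its nearest neighbour is compound 1; the step of a 1.7-fold higher number from compound 1 to compound 2 (0.22 log units; within the scatter) is within the scatter, so the two compounds cannot be ordered on this read-out. Compound 3 `Nc1ccc(Nc2nc3ccccc3nc2S(=O)(=O)c2ccc(Br)cc2)cc1` has not yet been measured in this assay. It differs from compound 2 by bromo in place of methoxy on an aromatic carbon, on an aromatic carbon of a six-membered aromatic ring of carbon only, para to a large group. Going by the values given here, no measured step touches a bromo group, and the one step that does touch this position, the methoxy for hydrogen change from compound 1 to compound 2, stayed within the scatter. The expectation for compound 3 is therefore a step of a 1.4-fold lower number from compound 2 to compound 3 (0.14 log units; within the scatter), not beyond the scatter. Compound 3 is estimated at 7000 nM, with a range from 2500 nM to 20000 nM.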

Compound 3, half-maximal inhibitory concentration: 2330 nM
Compound 3: middle estimate off by 3.0-fold (0.48 log units), on the high side, outside the stated range (below it).
By their numbers in this assay, from the lowest: compound 3; then compounds 1 and 2 (each within the scatter of the next).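

In this assay, the aromatic carbon para to a large group proves sensitive to what it carries: methoxy in place of hydrogen had stayed within the scatter, whereas bromo in place of methoxy gives a 4.1-fold lower number from compound 2 to compound 3 (0.62 log units; beyond the scatter). Bromo also separates from hydrogen at this carbon, with a 2.5-fold lower number from compound 1 to compound 3 (0.40 log units; beyond the scatter), so compound 3 stands lowest of the three and this is the first change here to move the number beyond the scatter. Nothing at hand explains why bromo differs from methoxy or hydrogen.

From the compounds shown here alone, whether this shift is particular to bromo or would also appear with chloro, fluoro or trifluoromethyl at this carbon remains open. So does how an amine or a carboxylic acid would read in the same place.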